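The source may hold more compounds than are shown below. What is called first, only, known or untested is meant among the compounds shown, and "the series" means these compounds.

Working notes on the series. Compound 1 `CSc1nc2c(C)nsc2n1[C@@H]1O[C@H](CO)[C@@H](O)[C@@H]1O` is the reference in a functional assay on L1210 cells (Mus musculus) for antiproliferative activity; on this read-out higher numbers stand for weaker inhibition and lower numbers for stronger inhibition. In this assay compound 1 reaches only the limit of > 100000 nM. Compound 2 `Cc1nsc2c1nc(SCc1ccccc1)n2[C@@H]1O[C@H](CO)[C@@H](O)[C@@H]1O` carries phenyl in place of hydrogen on a saturated chain carbon bound to a sulfur. In this assay compound 2 also stops at the limit of > 100000 nM. The step that the two limits leave unreadable from compound 1 to compound 2 cannot be sized because of the limit of > 100000 nM in this assay, at which 3 of the 3 values shown sit. Compound 3 `CSc1nc2c(C)nsc2n1[C@@H]1O[C@H](CO)[C@@H](O)[C@H]1O` shares the same atoms and bonds; the two cores differ only by the two compounds have the same atoms and bonds and differ only in configuration as drawn: 1 of 4 stereo elements differ; a stereocentre at a saturated ring carbon is drawn S in compound 1 and R in compound 3. In this assay compound 3 again gives only the limit of > 100000 nM. The step that the two limits leave unreadable from compound 1 to compound 3 is likewise unreadable, due to the fact that compounds 1 and 3 differ only in the configuration as drawn and (the limit of > 100000 nM in this assay, at which 3 of the 3 values shown sit). Compound 4 `Cc1nsc2c1nc(SCc1ccccc1)n2[C@@H]1O[C@H](CO)[C@@H](O)[C@H]1O` carries phenyl in place of hydrogen on a saturated chain carbon bound to a sulfur, the same change at the same place as from compound 1 to compound 2. For compound 4 the step that the limit leaves unreadable from compound 3 to compound 4 is expected, resting on the observation that the same change left compound 2 at a limit. Compound 4 is therefore estimated at 150000 nM, most likely reported only as a limit again.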

Compound 4, half-maximal inhibitory concentration: > 100000 nM
Compound 4 was reported as a limit; the forecaster's own chance of this, stated with the estimate: 85%; the middle value is on the limit's open side.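

In this assay compound 4 gives only a limit, as do compounds 2 and 3, so neither step to compound 4 can be read. The compounds shown leave open whether methylsulfanyl to benzylsulfanyl or the change in configuration alters inhibition at all.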